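The compounds below may be only part of what the source reports. "The series", "measured", "known", "first", "only" and "open" are said of these compounds alone.

Measured so far:
- compound 1 `NS(=O)(=O)c1ccc(N/C(S)=N\c2ccnc3cc(C(F)(F)F)ccc23)cc1`: 36600 nM
- compound 2 `O=S(=O)(Nc1ncccn1)c1ccc(N/C(S)=N\c2ccnc3cc(C(F)(F)F)ccc23)cc1`: "not active" (no number reported)

Within the data shown here, in a functional assay on HeLa cells (Homo sapiens) for antiproliferative activity, read by sulforhodamine B assay, with a stated time of 48 h (on this read-out higher numbers stand for weaker inhibition and lower numbers for stronger inhibition), compound 1 gives 36600 nM, the only number; compound 2 carries a pyrimidinyl group on the sulfonamide nitrogen and in this assay compound 2 is reported as "not active" (no number reported), with no number. Compound 3 `COc1cc(NS(=O)(=O)c2ccc(N/C(S)=N\c3ccnc4cc(C(F)(F)F)ccc34)cc2)nc(OC)n1` is not yet measured. It differs from compound 1 by 2,6-dimethoxypyrimidin-4-yl in place of hydrogen on a sulfonamide nitrogen. Among the measured compounds shown here, no step between two measured compounds is available to set the size of such a change. Compound 2 shows that a heteroaryl group on the sulfonamide nitrogen goes with no measurable activity, so the step from compound 1 to compound 3 is expected to weaken inhibition, plausibly beyond the scatter, as a 1.9-fold higher number from compound 1 to compound 3 (0.28 log units; within the scatter). Compound 3 is therefore expected at about 70000 nM, within 25000 nM to 200000 nM, with a fair chance that only a limit is reported.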

Compound 3, half-maximal inhibitory concentration: 53800 nM
Compound 3: the middle estimate sits 1.3-fold (0.11 log units) above what was measured, within the range that was stated.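

In this assay, 2,6-dimethoxypyrimidin-4-yl in place of hydrogen on the sulfonamide nitrogen gives a 1.5-fold higher number from compound 1 to compound 3 (0.17 log units; within the scatter), so even this group of 10 heavy atoms leaves the value unchanged within the scatter. A heteroaryl group on that nitrogen therefore does not always go with the absence of a number: compound 3 has a measured value, whereas compound 2, with its pyrimidinyl group, goes against this and stands as "not active". No evidence at hand bears on this difference between the two substituted compounds.

The compounds shown leave open whether the two methoxy groups or the way the ring is attached separate compound 3 from compound 2. They also leave open how a simple methyl or acetyl group on the sulfonamide nitrogen would compare with the hydrogen of compound 1.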